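The source may report more compounds than this note shows. Statements on the series, on what has been measured and on what is new or still open speak of the compounds shown alone.

Measured compounds in a physicochemical assay for solubility, at pH 2; on this read-out higher numbers stand for higher solubility and lower numbers for lower solubility:
- compound 1 `CNc1nc(NCCCN(C)C)c2sc(-c3ccc(-n4cccn4)cc3)cc2n1`: compound 1 gives 217 ug/mL
- compound 2 `CNc1nc(NCCCN(C)C)c2sc(-c3ccc(N)cc3)cc2n1`: compound 2 gives > 100 ug/mL, which is a limit of the assay
- compound 3 `CNc1nc(NCCCN(C)C)c2sc(-c3ccc(NS(C)(=O)=O)cc3)cc2n1`: compound 3 gives > 100 ug/mL, which is a limit of the assay

For the measured compounds named here, compound 3 stands only at a limit in this assay, the same limit at which compound 2 sits (the limit of > 100 ug/mL in this assay, at which 2 of the 3 values shown sit); compound 1 is the only member of the set with a read number. The step that the limit leaves unreadable from compound 1 to compound 3 and the step that the limit leaves unreadable from compound 1 to compound 2 are left unreadable by that limit, and the step that the two limits leave unreadable from compound 2 to compound 3 is left unreadable by two limits.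

Compound 4 `CNc1nc(NCCCN(C)C)c2sc(-c3ccc(N4CCNCC4)cc3)cc2n1` differs from compound 3 by piperazin-1-yl in place of methanesulfonamido on an aromatic carbon. Going by the values given here, no measured step reads cleanly on this change; the three values together show nothing below the limit anywhere in the set, and the one number, from compound 1, sits above it. The step from compound 3 to compound 4 is therefore expected to be a step that the limit leaves unreadable from compound 3 to compound 4, with no direction readable from the data. Compound 4 is expected to give 250 ug/mL in this assay, within 100 ug/mL to 700 ug/mL, and most likely to be reported again only as a limit.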

Compound 4, solubility: > 100 ug/mL
Compound 4 was reported as a limit; the forecaster's own chance of this, stated with the estimate: 65%; the middle value lies beyond the limit too.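

In this assay compound 4 gives > 100 ug/mL, which is a limit of the assay, so no new step can be read among compound 1, compound 2, compound 3 and compound 4: the limit of > 100 ug/mL in this assay, at which 3 of the 4 values shown sit.

As far as these compounds go, whether compound 2, compound 3 and compound 4 differ from one another or from compound 1 in this assay stays open.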